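The compounds below may be only part of what the source reports. "The series", "measured", "known", "first", "only" and "open" are said of these compounds alone.

Of the compounds shown here, two of one family have been measured so far. Compound 1 `Cc1cccc(/C(N)=N/NC(=S)N2CCSCC2)n1` carries a methyl group on its aromatic ring and, in a functional assay on HeLa cells (Homo sapiens) for cytotoxicity, read by MTT assay, with a stated time of 72 h, tested at 1 uM (a lower number here means less inhibition of growth, a higher number more inhibition of growth at the concentration tested), compound 1 gives 46.5%. Compound 2 `N/C(=N\NC(=S)N1CCSCC1)c1ccccn1` has hydrogen in place of that methyl, and in this assay compound 2 gives 25.1%. Among the measured compounds shown here, the step of a number 21.4 percentage points lower from compound 1 to compound 2 (beyond the scatter) is therefore the only measured change, and it is beyond the usual scatter. For the measured compounds named here, compound 2 stands lowest of the two numbers, with compound 1 as its only neighbour above it.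

The next compound, compound 3 `N/C(=N\NC(=S)N1CCCC1)c1ccccn1`, keeps the core of compound 2 but changes the ring attached to the thiocarbonyl carbon: pyrrolidin-1-yl in place of thiomorpholin-4-yl on a thiocarbonyl carbon. Going by the values given here, no measured step touches this part of the molecule; the one known step concerns the aromatic methyl, not the ring on the thiocarbonyl carbon, so it gives no guidance on size or direction here. The expectation for compound 3 is thus a step of a number 1.9 percentage points higher from compound 2 to compound 3 (within the scatter), meaning no change beyond the scatter. Compound 3 is estimated at 27%, within a range from 10% to 45%.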

Compound 3, percent growth inhibition at one concentration: 24.7%
For compound 3 the middle estimate is 2.3 percentage points above the measured one, and the stated range covers the measured number.
By their numbers in this assay, from the lowest: compounds 3 and 2 (each within the scatter of the next); then compound 1.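

In this assay, putting pyrrolidin-1-yl in place of thiomorpholin-4-yl on a thiocarbonyl carbon gives a number 0.4 percentage points lower from compound 2 to compound 3 (within the scatter), so compound 2 and compound 3 cannot be told apart. Among the compounds shown here, this is the first measured look at this position, and it shows that the ring here can become five-membered and lose its sulfur atom with no difference beyond the usual scatter, at least on the core without the aromatic methyl and at the single concentration tested. For the compounds shown here, the only step beyond the scatter remains the one at the aromatic carbon, a number 21.4 percentage points lower from compound 1 to compound 2 (beyond the scatter), and no measurement here explains why the two rings read alike.

Whether this tolerance extends to an open-chain dimethylamino group, or to a piperazine ring carrying a free amine, cannot be judged from these compounds, since both rings shown are compact, closed rings attached through nitrogen. Going by these compounds, it also remains open whether pyrrolidin-1-yl would read the same alongside the aromatic methyl of compound 1, the one place where a difference has appeared so far.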